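The compounds below may be only part of what the source reports. "The series", "measured", "known", "first", "only" and "open" are said of these compounds alone.

Measured so far:
Compound 1 `COc1cc2ncnc(Nc3cccc(Br)c3)c2cc1OCCCCC(=O)Nc1ccc(S(N)(=O)=O)cc1` gives 14900 nM in a functional assay on A549 cells (Homo sapiens) for antiproliferative activity, read by MTT assay, with a stated time of 72 h; a higher number here means a weaker inhibitor, a lower number a stronger inhibitor.
Compound 2 `COc1cc2ncnc(Nc3ccc(F)cc3)c2cc1OCCCCC(=O)Nc1ccc(S(N)(=O)=O)cc1` gives only a limit of the assay, > 40000 nM, in this assay.
Compound 3 `COc1ccc(Nc2ncnc3cc(OC)c(OCCCCC(=O)Nc4ccc(S(N)(=O)=O)cc4)cc23)cc1` likewise gives only a limit of the assay, > 40000 nM, in this assay.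

Compound 3 thus stands at the assay limit, one of two such values among the three, as the limit of > 40000 nM in this assay, at which 2 of the 3 values shown sit, records. Going by the values given here, the only readable number belongs to compound 1, and the two steps away from it are both at least modest rises: an at least 2.6-fold higher number from compound 1 to compound 2 (0.42 log units; beyond the scatter) and an at least 2.6-fold higher number from compound 1 to compound 3 (0.42 log units; beyond the scatter). The step between compound 2 and compound 3 cannot be read, since both sit at the limit.

Compound 4 `COc1cc2ncnc(Nc3cccc(C)c3)c2cc1OCCCCC(=O)Nc1ccc(S(N)(=O)=O)cc1` differs from compound 3 in one place: 3-methylphenyl in place of 4-methoxyphenyl on a nitrogen on an aromatic ring. Among the compounds with values here, the ring it gains resembles that of compound 1 in carrying its single substituent at the 3-position rather than the 4-position, and compound 1 is the one member with a readable number, 14900 nM. On that basis a modest fall from compound 3 is expected, an at least 1.6-fold lower number from compound 3 to compound 4 (0.20 log units; that floor lies within the scatter), though the limit leaves its true size open. Compound 4 is estimated at 25000 nM, within a range of 10000 nM to 60000 nM.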

Compound 4, half-maximal inhibitory concentration: 16000 nM
Compound 4: the middle estimate sits 1.6-fold (0.19 log units) above what was measured, and the stated range covers the measured number.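

Placing 3-methylphenyl on the nitrogen in place of 4-methoxyphenyl or 4-fluorophenyl brings the result off the limit, with an at least 2.5-fold lower number from compound 3 to compound 4 (0.39 log units; beyond the scatter) and an at least 2.5-fold lower number from compound 2 to compound 4 (0.39 log units; beyond the scatter). Until now, 3-bromophenyl was the only ring with a readable number, but the result also holds with methyl, as a 1.1-fold higher number from compound 1 to compound 4 (0.03 log units; within the scatter) leaves the two groups indistinguishable in this assay. Among the four compounds, the rings named 3-bromophenyl and 3-methylphenyl give readable numbers and those named 4-fluorophenyl and 4-methoxyphenyl do not, and no compound shown goes against this.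

From the compounds shown here alone, the true size of the first two steps stays open, since compound 2 and compound 3 each rest on a limit of the assay: the limit of > 40000 nM in this assay, at which 2 of the 4 values shown sit. Also open, going by these compounds, is whether a 3-methoxyphenyl or 3-aminophenyl ring would follow the same pattern.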